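The compounds below may be only part of what the source reports. "The series", "measured", "known", "first", "only" and "open" are said of these compounds alone.

Measured so far in a functional assay on HeLa cells (Homo sapiens) for antiproliferative activity, read by resazurin assay; on this read-out higher numbers stand for weaker inhibition and lower numbers for stronger inhibition:
- compound 1 `Cc1ccc(C(=O)CSC(=S)SC(C)(C)C)cc1`: 31600 nM
- compound 2 `CCOC(=O)Nc1cccc(C(=O)CSC(=S)SCC)c1`: 2000 nM
- compound 3 `COc1ccc(C(=O)CS)cc1`: 20000 nM

Compound 2 has the lowest number of the three, 2000 nM, which makes it the strongest inhibitor here. The gaps up to compound 3 and compound 1 both lie beyond the scatter. Compound 4 `CCSC(=S)SCC(=O)c1cccc(OC)c1` has not yet been measured. It carries methoxy in place of (ethoxycarbonyl)amino on an aromatic carbon of compound 2: methoxy in place of (ethoxycarbonyl)amino on an aromatic carbon.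

Going by the values given here, no measured pair shows this change alone, so any expectation is uncertain. Only compound 2 carries (ethoxycarbonyl)amino. Compound 3, which carries methoxy but also differs in other places, gives 20000 nM. That value points towards weaker inhibition in this assay, though probably not all the way to that level, since compound 4 keeps the rest of compound 2. A moderate upward step is therefore expected, estimated as a 3.0-fold higher number from compound 2 to compound 4 (0.48 log units; beyond the scatter). For compound 4 the estimated value is 6000 nM, with an expected range of 2000 nM to 20000 nM.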

Compound 4, half-maximal inhibitory concentration: 5010 nM
Compound 4: the middle estimate sits 1.2-fold (0.08 log units) above what was measured; low and high end bracket the measured number.
By their numbers in this assay, from the lowest: compound 2; then compound 4; then compounds 3 and 1 (each within the scatter of the next).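

Going by these compounds alone, replacing (ethoxycarbonyl)amino with methoxy on this aromatic carbon gives a 2.5-fold higher number from compound 2 to compound 4 (0.40 log units; beyond the scatter) in this assay, the first comparison here in which only one place changes. The step is modest but beyond the scatter, so this position does affect the read-out, yet compound 4 with the much smaller methoxy still reaches 5010 nM and keeps much of the inhibition seen with compound 2. No measurement shown here explains why the number rises with this change.

Going by these compounds, it remains open whether a free amino group or an acetylamino group on this aromatic carbon would match (ethoxycarbonyl)amino or methoxy. It is also unclear whether a step of this size would recur with a longer chain in place of the ethyl group on sulfur.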